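Swapping the aryl group on a sulfonamide

The source may hold more compounds than are shown below. What is called first, only, known or untested is meant among the compounds shown, and "the series" means these compounds.

In a functional assay on HepG2 cells (Homo sapiens) for antiproliferative activity, read by MTT assay, with a stated time of 48 h (a higher number here means a weaker inhibitor, a lower number a stronger inhibitor), compound 2 `CCOc1ccc(-c2sc(N)nc2-c2cc(OC)c(OC)c(OC)c2)cc1` gives 8.3 nM as a measured number. Compound 1 `CCOc1ccc(-c2nc(N(Cc3ccccc3)Cc3ccccc3)sc2-c2cc(OC)c(OC)c(OC)c2)cc1` gives > 5000 nM here, which is a limit and not a number. Compound 3 `CCOc1ccc(-c2nc(NS(=O)(=O)c3ccc([N+](=O)[O-])cc3OC)sc2-c2cc(OC)c(OC)c(OC)c2)cc1` gives > 5000 nM here, again a limit. Compound 3 thus stands at the limit of > 5000 nM in this assay, at which 2 of the 3 values shown sit, and has no exact value. Compound 4 `CCOc1ccc(-c2nc(NS(=O)(=O)c3ccc(C)c(C)c3)sc2-c2cc(OC)c(OC)c(OC)c2)cc1` carries 3,4-dimethylphenyl in place of 2-methoxy-4-nitrophenyl on a sulfonyl sulfur. Going by the values given here, no measured pair shows this swap, so in this assay no step beyond the scatter is expected in either direction. This expectation rests on compound 3, whose > 5000 nM is only a limit. In numbers the expected move is a number no higher from compound 3 to compound 4 (the limit leaves the size open) on this estimate. For compound 4 the estimated value is 5000 nM (expected range 1000 nM to 20000 nM).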

Compound 4, half-maximal inhibitory concentration: > 5000 nM
Compound 4: only a limit was reported (the forecaster's own chance of this, stated with the estimate: 70%); the middle value lies on the limit itself.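

No step can be read from compound 3 to compound 4: in this assay both are reported only as a limit. Going by these compounds, the exact value of each compound stays open, and with it whether 3,4-dimethylphenyl in place of 2-methoxy-4-nitrophenyl on a sulfonyl sulfur changes the activity at all.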